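Replacing an iodophenyl with a dimethoxyphenyl on the amine

The compounds below may be only part of what the source reports. "The series", "measured", "known", "first", "only" and "open" are said of these compounds alone.

Of the compounds shown here, three sharing one core have been tested in a functional assay on DU-145 cells (Homo sapiens) for cytotoxicity, read by MTT assay, with a stated time of 48 h; on this read-out higher numbers stand for weaker inhibition and lower numbers for stronger inhibition. Compound 1 `COc1ccc(N/C(CCNC2=CC(=O)c3ccccc3C2=O)=N\S(=O)(=O)c2ccc(C)cc2)cc1` gives 12000 nM. Compound 2 `Cc1ccc(S(=O)(=O)/N=C(/CCNC2=CC(=O)c3ccccc3C2=O)Nc2ccccc2[N+](=O)[O-])cc1` gives 7590 nM. Compound 3 `Cc1ccc(S(=O)(=O)/N=C(/CCNC2=CC(=O)c3ccccc3C2=O)Nc2ccccc2I)cc1` gives 11700 nM, which places it second highest of the three, with compound 1 nearest and compound 2 furthest, both within the scatter. The steps among the measured compounds are all small: a 1.6-fold lower number from compound 1 to compound 2 (0.20 log units; within the scatter), a 1.0-fold lower number from compound 1 to compound 3 (0.01 log units; within the scatter) and a 1.5-fold higher number from compound 2 to compound 3 (0.19 log units; within the scatter).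

Compound 4 `COc1ccc(N/C(CCNC2=CC(=O)c3ccccc3C2=O)=N\S(=O)(=O)c2ccc(C)cc2)cc1OC` has not yet been measured. It differs from compound 3 by 3,4-dimethoxyphenyl in place of 2-iodophenyl on an amine nitrogen. The step bearing most on this change is a 1.0-fold lower number from compound 1 to compound 3 (0.01 log units; within the scatter), since compound 1 already carries a methoxy-bearing aryl on that nitrogen, and the aryl exchanges seen so far left this assay unchanged beyond the scatter. Compound 4 is therefore expected to show no step beyond the scatter, a 1.1-fold lower number from compound 3 to compound 4 (0.03 log units; within the scatter). The estimate for compound 4 in this assay is 11000 nM, with a range from 5000 nM to 25000 nM.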

Compound 4, half-maximal inhibitory concentration: 17800 nM
Compound 4: middle estimate off by 1.6-fold (0.21 log units), on the low side; low and high end bracket the measured number.
By their numbers in this assay, from the lowest: compounds 2, 3, 1 and 4 (each within the scatter of the next, the first and the last beyond it).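

In this assay the aryl on the amine nitrogen now yields the only step beyond the scatter among these compounds, a 2.3-fold higher number from compound 2 to compound 4 (0.37 log units; beyond the scatter), so exchanging 2-nitrophenyl for 3,4-dimethoxyphenyl at this position does register, though modestly. The other two steps stay within the scatter: a 1.5-fold higher number from compound 3 to compound 4 (0.18 log units; within the scatter) for 3,4-dimethoxyphenyl in place of 2-iodophenyl, and a 1.5-fold higher number from compound 1 to compound 4 (0.17 log units; within the scatter) for the added methoxy on an aromatic carbon, so neither change can be told apart from no change at all. Among the compounds shown here, nothing available accounts for the one step that exceeds the scatter.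

As far as these compounds go, it remains open whether that step rests on the loss of the nitro group or on the arrival of the methoxy groups. Also open, from the compounds shown here alone, is how this read-out would respond to a benzyl or cyclohexyl group on this nitrogen in place of the aryl rings seen so far.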